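Methyl in Place of Fluoro: Expectation for Compound 4

The source may hold more compounds than are shown below. What is called first, only, known or untested is meant among the compounds shown, and "the series" means these compounds.

Measured so far:
compound 1 `Oc1ccccc1CNc1ccc(-c2cccc(F)c2)cc1` — 2020 nM
compound 2 `Cc1cccc(-c2ccc(NCc3ccccc3O)cc2)c1` — 9190 nM
compound 3 `Oc1ccccc1CNc1ccc(-c2ccccc2)cc1F` — 5350 nM

All three were tested in a functional assay on Jurkat cells (Homo sapiens) for activation, with a stated time of 24 h; a lower number here means that less compound is needed, a higher number that more compound is needed for the effect. Compound 1 and compound 2 differ by methyl in place of fluoro on an aromatic carbon, and that change gave a 4.5-fold higher number from compound 1 to compound 2 (0.66 log units; beyond the scatter). Compound 4 `Cc1cc(-c2ccccc2)ccc1NCc1ccccc1O` differs from compound 3 by methyl in place of fluoro on an aromatic carbon. The same kind of change is made, but the place is not identical: in compound 1 the fluoro sits meta to a large group, whereas in compound 3 it sits ortho to a group of 9 heavy atoms and meta to a phenyl group. How the core of compound 3 differs from the core of compound 1 is not broken down here. A step like the earlier one is expected, so a 3.0-fold higher number from compound 3 to compound 4 (0.48 log units; beyond the scatter) is estimated, resting on a 4.5-fold higher number from compound 1 to compound 2 (0.66 log units; beyond the scatter). For compound 4 the expected value in this assay is 16000 nM, between 5000 nM and 50000 nM.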

Compound 4, half-maximal effective concentration: "not active" (no number reported)
Compound 4: no number reported, and the estimate cannot be compared.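

Among the compounds shown here, compound 4 was reported as "not active" without a number, so no step from compound 3 to compound 4 can be read. From the compounds shown here alone, how far methyl in place of fluoro at this place shifts the number stays open. No measured evidence bears on this result.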